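Nitro in place of hydroxy on compound 2

The source may hold more compounds than are shown below. What is called first, only, known or untested is meant among the compounds shown, and "the series" means these compounds.

In a functional assay on HT-1080 cells (Homo sapiens) for antiproliferative activity, read by MTT assay, with a stated time of 72 h (on this read-out lower numbers stand for stronger inhibition and higher numbers for weaker inhibition), compound 1 `COc1ccc(-c2ssc(=S)c2-c2cc(OC)c(OC)c(OC)c2)cc1` gives 18600 nM and compound 2 `COc1ccc(-c2ssc(=S)c2-c2cc(OC)c(OC)c(OC)c2)cc1O` gives 231 nM as the lower of the two numbers. Among the compounds with values here, the change nitro in place of hydroxy on an aromatic carbon puts nitro in place of hydroxy on an aromatic carbon and leads to compound 3 `COc1ccc(-c2ssc(=S)c2-c2cc(OC)c(OC)c(OC)c2)cc1[N+](=O)[O-]` which has no measurement yet in this assay at this stage. Within the data shown here, one measured step bears on it: an 81-fold lower number from compound 1 to compound 2 (1.91 log units; beyond the scatter) is large and beyond the scatter, and it comes with hydroxy in place of hydrogen on that same carbon. Among the measured compounds shown here, compound 3 lacks this hydroxy, so much of that drop is expected to be given back, although no nitro compound has been measured. The estimate is a 17-fold higher number from compound 2 to compound 3 (1.24 log units; beyond the scatter) towards a higher number, beyond the scatter but short of the full measured step. For compound 3 the expected value is 4000 nM within an estimated range of 700 nM to 20000 nM for now.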

Compound 3, half-maximal inhibitory concentration: 9140 nM
Compound 3: the middle estimate sits 2.3-fold (0.36 log units) below what was measured, and the stated range covers the measured number.
By their numbers in this assay, from the lowest: compound 2; then compound 3; then compound 1.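

At this aromatic carbon, ortho to a methoxy group, nitro does not stand in for hydroxy: in this assay the exchange gives a 40-fold higher number from compound 2 to compound 3 (1.60 log units; beyond the scatter) and removes most of the advantage of compound 2. Nitro in place of hydrogen gives only a 2.0-fold lower number from compound 1 to compound 3 (0.31 log units; beyond the scatter) as a modest step, so among the groups shown, the large change in this read-out goes with hydroxy and not with substitution of this carbon as such. No measurement at hand accounts for the difference between hydroxy and nitro.

The compounds shown leave open whether an amine or a carboxylic acid at this carbon would come close to compound 2. They also leave open whether hydroxy on another carbon of this ring would bring a similar change.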